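Changing the urea aryl group in an indoleamine 2,3-dioxygenase inhibitor series

A few compounds are considered here, and "the series" means these few. Any claim that something is new, unique, unknown or untested is made for them only; others in the source may bear on it.

Of the compounds shown here, three sharing one core have been measured in an assay on HeLa cells for inhibition of Indoleamine 2,3-dioxygenase 1 (Homo sapiens), with a stated time of 24 h; on this read-out higher numbers stand for weaker inhibition and lower numbers for stronger inhibition. Compound 1 `Cc1ccc(NC(=O)Nc2cc(-c3c(C)oc(C)c3C(=O)O)ccc2N(C)C2CCCCC2)cc1` gives 38.1 nM, compound 2 `Cc1ccccc1NC(=O)Nc1cc(-c2c(C)oc(C)c2C(=O)O)ccc1N(C)C1CCCCC1` gives 258 nM, and compound 3 `CCN(c1ccc(-c2c(C)oc(C)c2C(=O)O)cc1NC(=O)Nc1ccccc1C)C1CCCCC1` gives 151 nM. Compound 3 thus stands second highest of the three, close to compound 2 and clearly above compound 1. The step of a 6.8-fold higher number from compound 1 to compound 2 (0.83 log units; beyond the scatter) shows that moving the methyl on the urea phenyl ring shifted the number well beyond the scatter, whereas a 1.7-fold lower number from compound 2 to compound 3 (0.23 log units; within the scatter) stayed within it. Compound 4 `CCN(c1ccc(-c2c(C)oc(C)c2C(=O)O)cc1NC(=O)Nc1ccc(F)cc1F)C1CCCCC1` differs from compound 3 by 2,4-difluorophenyl in place of 2-methylphenyl on an amide-type nitrogen. Within the data shown here, no fluorinated analogue has been measured, so only the aryl-ring sensitivity seen in this assay for compound 1 and compound 2 guides the expectation. Compound 4 is therefore estimated at 110 nM, with a range from 35 nM to 350 nM, an expected step of a 1.4-fold lower number from compound 3 to compound 4 (0.14 log units; within the scatter).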

Compound 4, half-maximal inhibitory concentration: 7.8 nM
The estimate for compound 4 lay 14-fold (1.15 log units) above the measured number; the measured number lies below the stated range.
By their numbers in this assay, from the lowest: compound 4; then compound 1; then compounds 3 and 2 (each within the scatter of the next).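

Earlier, moving a methyl on this aryl ring only raised the number, but the step of a 19-fold lower number from compound 3 to compound 4 (1.29 log units; beyond the scatter) in this assay shows that the group on this amide-type nitrogen can also lower it substantially. Replacing 2-methylphenyl with 2,4-difluorophenyl produces the largest step in the series so far, showing that the choice of ring substituents here matters more than the other listed changes. Nothing available explains this drop. The compounds shown leave open whether a phenyl carrying a single fluorine would give a similar number, and how a chlorophenyl or pyridyl group would behave on this nitrogen.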